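Removing the Aryl Group from the Ring Amine Nitrogen

The source may hold more compounds than are shown below. What is called first, only, known or untested is meant among the compounds shown, and "the series" means these compounds.

Compound 1 `Cc1ccc(-[n+]2noc([O-])c2CN2CCN(C)CC2)cc1`: 100 ug/mL
Compound 2 `Cc1ccc(-[n+]2noc([O-])c2CN2CCN(c3cccc(Cl)c3Cl)CC2)cc1`: 20 ug/mL
Compound 3 `Cc1ccc(-[n+]2noc([O-])c2CN2CCN(c3cccc(Cl)c3)CC2)cc1`: 100 ug/mL

In an ADME assay on HEL cells (Homo sapiens) for cytotoxicity (a lower number here means that less compound is tolerated, a higher number that more compound is tolerated), compound 3 stands level with compound 1, the two together giving the highest of the three numbers; compound 2 is the furthest from it, a 5.0-fold higher number from compound 2 to compound 3 (0.70 log units; beyond the scatter). Compound 4 `Cc1ccc(-[n+]2noc([O-])c2CN2CCNCC2)cc1` differs from compound 3 by hydrogen in place of 3-chlorophenyl on an amine nitrogen in a ring. Among the measured compounds shown here, two measured steps bear on this change at the same position: no change at the digits printed from compound 1 to compound 3 (within the scatter), and a 5.0-fold lower number from compound 1 to compound 2 (0.70 log units; beyond the scatter). Only the dichlorophenyl step moved beyond the scatter, and compound 4 carries no such group, so no step beyond the scatter is expected. Compound 4 is therefore estimated at 100 ug/mL, with a range of 50 ug/mL to 200 ug/mL, an expected step of no change at the digits printed from compound 3 to compound 4 (within the scatter) from compound 3.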

Compound 4, minimum cytotoxic concentration: 100 ug/mL
The estimate for compound 4 equals the measured number at the digits printed; the range from low to high includes it.
By their numbers in this assay, from the lowest: compound 2; then compounds 1, 3 and 4 (each within the scatter of the next).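

In this assay the ring amine nitrogen now also bears plain hydrogen, and replacing 3-chlorophenyl gives no change at the digits printed from compound 3 to compound 4 (within the scatter) while replacing methyl gives no change at the digits printed from compound 1 to compound 4 (within the scatter) on the same nitrogen. Among the four compounds, only the 2,3-dichlorophenyl group stands apart, with hydrogen in its place giving a 5.0-fold higher number from compound 2 to compound 4 (0.70 log units; beyond the scatter) in this series. No measurement at hand accounts for that difference. On these data alone, it remains open whether a benzyl group, an acetyl group or an unsubstituted phenyl ring on this nitrogen would stay level with compound 4.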